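Removing the Bromo from an Anilide Series on KYSE-450

This account rests on a few compounds, and the source may have more. Where it says the series, first, only, none or still open, it means among the compounds named here.

Compound 2 `COc1ccc(CN(C(=O)C(C)Br)c2cc(OC)c(OC)c(OC)c2)cc1O` stands lowest of the three numbers in a functional assay on KYSE-450 cells (Homo sapiens) for inhibition, read by MTT assay, with a stated time of 48 h (a higher number here means a weaker inhibitor, a lower number a stronger inhibitor), where compound 2 gives 160 nM. Compound 1 `COc1ccc(CNc2cc(OC)c(OC)c(OC)c2)cc1[N+](=O)[O-]` gives 16800 nM and compound 3 `COc1ccc(N(Cc2cc(OC)c(OC)c(OC)c2)C(=O)CCl)cc1O` gives 29800 nM; both differ from compound 2 in more than one place, so only their values are compared, and each lies well beyond the scatter above compound 2. Compound 4 `CCC(=O)N(Cc1ccc(OC)c(O)c1)c1cc(OC)c(OC)c(OC)c1` differs from compound 2 in a single way: hydrogen in place of bromo on a saturated chain carbon bound to a carbonyl carbon and a saturated chain carbon. Among the measured compounds shown here, with no single-change step recorded, the account rests on compound 2 alone, the only compound carrying the bromo and the only one with a low number. Compound 4 is therefore expected to lose potency, the step of a 19-fold higher number from compound 2 to compound 4 (1.27 log units; beyond the scatter) estimated as large. Compound 4 is estimated at 3000 nM, within 400 nM to 25000 nM.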

Compound 4, half-maximal inhibitory concentration: 98 nM
Compound 4: the middle estimate sits 31-fold (1.49 log units) above what was measured, outside the stated range (below it).
By their numbers in this assay, from the lowest: compounds 4 and 2 (each within the scatter of the next); then compounds 1 and 3 (each within the scatter of the next).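

In this assay the change from bromo to hydrogen on this saturated chain carbon is a 1.6-fold lower number from compound 2 to compound 4 (0.21 log units; within the scatter) and so the low number of compound 2 does not rest on the bromo. The 1-bromoethyl and ethyl forms cannot be told apart here, and the earlier link between the bromo and a low number came only from compound 2 standing alone. Nothing measured here gives a reason for this result. Still open, from the compounds shown here alone, is whether an amine, a hydroxyl or a longer chain on this carbon would keep the number as low.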